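The compounds below may be only part of what the source reports. "The series", "measured", "known", "first", "only" and "open" are said of these compounds alone.

Three compounds of this series have numbers in a functional assay on PC-3 cells (Homo sapiens) for antiproliferative activity, read by MTT assay, tested at 1 uM; a higher number here means a stronger effect of the compound at the concentration tested, a lower number a weaker effect. Compound 1 `COc1cc(C(=O)N/N=C/c2ccccc2F)cc(OC)c1OC` gives 70.6%. Compound 2 `COc1cc(C(=O)N/N=C/c2ccc(F)c(F)c2)cc(OC)c1OC` gives 35.1%. Compound 3 `COc1cc(C2=NN(C(C)=O)C(c3ccc(F)c(F)c3)O2)cc(OC)c1OC`, which carries the same 3,4-difluorophenyl group on a different core, gives 35.5%. Going by the values given here, on these numbers compound 2 stands lowest of the three, with compound 3 within the scatter of it and compound 1 well above it; the one step that reaches compound 2 is a number 35.5 percentage points lower from compound 1 to compound 2 (beyond the scatter), a large drop.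

Compound 4 `COc1cc(C(=O)N/N=C/c2cccc(F)c2)cc(OC)c1OC` has not yet been measured in this assay. Its difference from compound 2 is hydrogen in place of fluoro on an aromatic carbon. Among the compounds with values here, no measured step removes a single fluoro group from a ring that keeps another; the only step that bears on the question is a number 35.5 percentage points lower from compound 1 to compound 2 (beyond the scatter), which changed the fluoro pattern on the same ring and was large. A step of comparable size therefore cannot be ruled out for compound 4, but its direction is not fixed by the data, and a number anywhere between the values of compound 2 and compound 1 would be consistent with what is known. Compound 4 is expected to come out near 48%, in a range from 22% to 74%. This corresponds to an expected step of a number 12.9 percentage points higher from compound 2 to compound 4 (beyond the scatter).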

Compound 4, a percentage reported as inhibition, at one concentration (the size of the read-out at that concentration, not a potency): 53.5%
Beside the measured number, compound 4's estimate is 5.5 percentage points below it, within the range that was stated.
By their numbers in this assay, from the lowest: compounds 2 and 3 (each within the scatter of the next); then compound 4; then compound 1.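

Going by these compounds alone, with the core and the 3-fluorophenyl fluoro group held constant, the aromatic carbon para to a large group proves sensitive in this assay: hydrogen in place of fluoro there gives a number 18.4 percentage points higher from compound 2 to compound 4 (beyond the scatter) in this series, so the single fluoro group at this position is enough to shift the read-out beyond the scatter. Fluoro placement also matters among the two compounds with one ring fluoro group, with a number 17.1 percentage points lower from compound 1 to compound 4 (beyond the scatter) on going from the 2-fluorophenyl to the 3-fluorophenyl group, and compound 4 now stands between the two ends of the large fall seen from the 2-fluorophenyl to the 3,4-difluorophenyl group. No measurement at hand accounts for either step.

As far as these compounds go, whether the rise belongs to hydrogen specifically remains open, as chloro, methoxy or an amine on that same carbon could tell whether any replacement of fluoro gives a similar number. From the compounds shown here alone, it also remains open whether the same change carries over to the core of compound 3, which bears the 3,4-difluorophenyl group, and all of these readings rest on a single tested concentration.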